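This account rests on a few compounds, and the source may have more. Where it says the series, first, only, none or still open, it means among the compounds named here.

Compound 2 `COc1ccc(-n2nc(Sc3ccc(Cl)cc3)cc(CC[C@@H](C)NC(=O)[C@H]3CNCC[C@@H]3c3ccccc3F)c2=O)cc1`: 13 nM
Compound 1 `COc1ccc(-n2nc(Sc3ccc(Cl)cc3)cc(CC[C@@H](C)NC(=O)[C@H]3CNCC[C@@H]3c3cccc(Cl)c3)c2=O)cc1`: 43 nM

For the measured compounds named here, in an assay on CHO cells for binding affinity to Melanocortin receptor 4 (Homo sapiens) (a higher number here means a weaker inhibitor, a lower number a stronger inhibitor), compound 2 gives 13 nM, the lowest of the two numbers measured so far; its nearest neighbour is compound 1, which gives 43 nM. Going by the values given here, the one measured step that bears here, a 3.3-fold lower number from compound 1 to compound 2 (0.52 log units; beyond the scatter), shows how much the group on the saturated ring carbon can move the number. Compound 3 `COc1ccc(-n2nc(Sc3ccc(Cl)cc3)cc(CC[C@@H](C)NC(=O)[C@H]3CNCC[C@@H]3c3cccc(C(F)(F)F)c3)c2=O)cc1` differs from compound 2 in that place: 3-(trifluoromethyl)phenyl in place of 2-fluorophenyl on a saturated ring carbon. The change brings back a group at the same position of the phenyl ring as in compound 1, now a larger one, so a move back toward the number of compound 1, or a little past it, is expected, and the expected step is a 3.1-fold higher number from compound 2 to compound 3 (0.49 log units; beyond the scatter). For compound 3 in this assay the estimate is 40 nM, with a likely range from 15 nM to 120 nM.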

Compound 3, half-maximal inhibitory concentration: 100 nM
Estimate against measurement, compound 3: 2.5-fold (0.40 log units) below, within the range that was stated.
By their numbers in this assay, from the lowest: compound 2; then compound 1; then compound 3.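

Within this assay, the 2-fluorophenyl of compound 2 now stands apart from two different groups at this saturated ring carbon: replacing it with 3-(trifluoromethyl)phenyl gives a 7.7-fold higher number from compound 2 to compound 3 (0.89 log units; beyond the scatter). The two compounds with a group at the 3 position of the phenyl ring also differ from each other, as 3-(trifluoromethyl)phenyl in place of 3-chlorophenyl gives a 2.3-fold higher number from compound 1 to compound 3 (0.37 log units; beyond the scatter), so the choice of that group moves the number as well. Nothing given here explains either step.

Each step away from compound 2 changes both the group on the phenyl ring and its position, so these compounds cannot separate the two effects. A 3-fluorophenyl or a 2-chlorophenyl at this carbon would bear on that question, and an unsubstituted phenyl would show what any group on the ring adds.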